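The source may report more compounds than this note shows. Statements on the series, on what has been measured and on what is new or still open speak of the compounds shown alone.

Of the compounds shown here, two have been measured in an assay for inhibition of 6-phosphofructo-2-kinase/fructose-2,6-bisphosphatase 3 (Homo sapiens), read by ADP-Glo, with a stated time of 2 h; on this read-out lower numbers stand for stronger inhibition and higher numbers for weaker inhibition. Compound 1, `CNS(=O)(=O)c1ccccc1Nc1cc(-c2ccc3ccn(C)c3c2)c2nccnc2c1`, gives 104 nM in this assay. Compound 2, `Cn1ccc2ccc(-c3cc(Nc4cnccc4C(=O)NC4CCNC(=O)C4)cc4nccnc34)cc21`, gives 69 nM in this assay, and the two numbers lie within the scatter of each other, so neither compound can be called the stronger inhibitor on this evidence.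

Compound 3, `CC(=O)N1CC(CNC(=O)c2ccncc2Nc2cc(-c3ccc4ccn(C)c4c3)c3nccnc3c2)C1`, has not yet been measured. It differs from compound 2 in one place: (1-acetylazetidin-3-yl)methyl in place of 2-oxopiperidin-4-yl on an amide-type nitrogen. The rest of the molecule, including the shared core, is unchanged.

Among the measured compounds shown here, no pair of measured compounds shows what such a change at the amide-type nitrogen does, so the expectation rests only on the size of the change and on the value of compound 2 in this assay. A step of a 2.2-fold higher number from compound 2 to compound 3 (0.34 log units; beyond the scatter) is expected from compound 2 to compound 3, a mild move toward weaker inhibition that may not exceed the scatter. Compound 3 is therefore estimated at 150 nM in this assay, with a plausible range from 50 nM to 500 nM.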

Compound 3, half-maximal inhibitory concentration: 137 nM
Estimate against measurement, compound 3: 1.1-fold (0.04 log units) above, within the range that was stated.
By their numbers in this assay, from the lowest: compounds 2, 1 and 3 (each within the scatter of the next).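

In this assay, among the compounds shown here, putting (1-acetylazetidin-3-yl)methyl in place of 2-oxopiperidin-4-yl on the amide-type nitrogen gives a 2.0-fold higher number from compound 2 to compound 3 (0.30 log units; within the scatter) and so offers the first direct look at this position: in this one pair, the two groups cannot be told apart. The entering group has a four-membered rather than a six-membered non-aromatic ring and has no hydrogen-bond donor, whereas the leaving group has one, so neither that donor nor the six-membered ring is shown to be needed for a value in this range. No measurement here accounts for how closely the two numbers lie.

Going by these compounds, both groups carry no net charge and each holds a carbonyl, so it remains open whether an amine, such as piperidin-4-yl with a free ring nitrogen, or a carboxylic acid on a short chain would read differently at this nitrogen. Also open, on these data alone, is what a plain alkyl chain would do here, or a methyl group in place of the amide hydrogen.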